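Methoxy to hydroxy on the aryl of the pyrazole series

The source may report more compounds than this note shows. Statements on the series, on what has been measured and on what is new or still open speak of the compounds shown alone.

Two members of the series have numbers in a functional assay on SF-295 cells (Homo sapiens) for inhibition, read by sulforhodamine B assay, with a stated time of 48 h; a higher number here means a weaker inhibitor of growth, a lower number a stronger inhibitor of growth. Compound 1 `O=C(Nc1cccc(-n2cc(-c3ccncc3)c(-c3ccc(Cl)c(O)c3)n2)c1)Nc1cccc(C(F)(F)F)c1` gives 4260 nM. Compound 2 `COc1cc(-c2nn(-c3cccc(NC(=O)Nc4cc(C(F)(F)F)cc(C(F)(F)F)c4)c3)cc2-c2ccncc2)ccc1Cl` gives 1230 nM, the lowest of the two numbers, with compound 1 giving a higher number, beyond the scatter. Compound 3 `O=C(Nc1cccc(-n2cc(-c3ccncc3)c(-c3ccc(Cl)c(O)c3)n2)c1)Nc1cc(C(F)(F)F)cc(C(F)(F)F)c1` is not yet measured; it differs from compound 2 by hydrogen in place of methyl on an oxygen on an aromatic ring. Among the measured compounds shown here, no measured pair isolates this change, so the expectation rests on the two numbers alone. A small step toward a higher number, or none beyond the scatter, is expected: a 1.5-fold higher number from compound 2 to compound 3 (0.17 log units; within the scatter). Compound 3 is estimated at 1800 nM, within 700 nM to 5000 nM.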

Compound 3, concentration for total growth inhibition: 1650 nM
Estimate against measurement, compound 3: 1.1-fold (0.04 log units) above, and the stated range covers the measured number.
By their numbers in this assay, from the lowest: compounds 2 and 3 (each within the scatter of the next); then compound 1.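

In this assay, methoxy to hydroxy on the 4-chloro-3-methoxyphenyl group can now be read as a single change: a 1.3-fold higher number from compound 2 to compound 3 (0.13 log units; within the scatter), so either group is accommodated here with the rest of compound 2 held. With hydroxy held, trifluoromethyl in place of hydrogen on an aromatic carbon gives a 2.6-fold lower number from compound 1 to compound 3 (0.41 log units; beyond the scatter), and of the two changes only this one lies beyond the scatter. No available data bear on the reason for either step. Going by these compounds, whether an amine, a carboxylic acid or an ethoxy group would fit at this oxygen-bearing position remains open. So does whether methoxy to hydroxy reads the same on the core of compound 1.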